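Furan to thiophene on a growth-inhibiting core

This account rests on a few compounds, and the source may have more. Where it says the series, first, only, none or still open, it means among the compounds named here.

Measured in a functional assay on RPTEC cells (Homo sapiens) for antiproliferative activity; on this read-out higher numbers stand for weaker inhibition of growth and lower numbers for stronger inhibition of growth:
- compound 1 `c1ccc(-c2cc(-c3ccccn3)nc(-c3ccccn3)c2)cc1`: 0.027 ug/mL
- compound 2 `c1ccc(-c2cc(-c3ccco3)cc(-c3ccccn3)n2)nc1`: 0.0041 ug/mL

Of these two numbers, the lower belongs to compound 2. Compound 3 `c1ccc(-c2cc(-c3cccs3)cc(-c3ccccn3)n2)nc1` differs from it in one place: thiophen-2-yl in place of furan-2-yl on an aromatic carbon. Thiophen-2-yl stands in place of furan-2-yl on an aromatic carbon. Going by the values given here, only one measured step bears on this: a 6.6-fold lower number from compound 1 to compound 2 (0.82 log units; beyond the scatter), with furan-2-yl replacing phenyl. Among the compounds with values here, no measurement yet compares furan-2-yl with thiophen-2-yl directly. Both are five-membered aromatic rings with 1 hetero atom, so a much smaller move in this assay is expected, none beyond the scatter, leaning towards a higher number. The expected step is a 1.5-fold higher number from compound 2 to compound 3 (0.17 log units; within the scatter). Compound 3 is estimated at 0.006 ug/mL, within a range of 0.002 ug/mL to 0.018 ug/mL.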

Compound 3, concentration for 50% growth inhibition: 0.0016 ug/mL
For compound 3 the middle estimate is 3.8-fold (0.57 log units) above the measured one; measured number outside the range, below it.
By their numbers in this assay, from the lowest: compound 3; then compound 2; then compound 1.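

At this place, opposite the ring nitrogen, the identity of the hetero atom matters in this assay: thiophen-2-yl in place of furan-2-yl gives a 2.6-fold lower number from compound 2 to compound 3 (0.41 log units; beyond the scatter), so two rings of the same size and hetero atom count are not interchangeable here. Thiophen-2-yl in place of phenyl gives a 17-fold lower number from compound 1 to compound 3 (1.23 log units; beyond the scatter), a larger step than furan-2-yl gave. Nothing available explains why sulfur gives the lower number. As far as these compounds go, whether an amine or a carboxylic acid on the thiophen-2-yl ring would keep this number remains open, as does a piperidine at this place.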